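Chloro to nitro on compound 3

The compounds below may be only part of what the source reports. "The series", "measured", "known", "first", "only" and "open" are said of these compounds alone.

Values in a toxicity assay on THP-1 cells (Homo sapiens) for inhibition; on this read-out lower numbers stand for higher toxicity in this test and higher numbers for lower toxicity in this test:
Compound 1 `Cn1c(-c2ccc(Br)cc2)cnc1NC(=O)c1ccc(F)cc1` gives 46000 nM
Compound 2 `Cn1c(-c2ccccc2Cl)cnc1NC(=O)c1ccc(F)cc1` gives > 50000 nM, which is a limit of the assay
Compound 3 `Cn1c(-c2ccc(Cl)cc2)cnc1NC(=O)c1ccc(F)cc1` gives 37000 nM
Compound 4 `Cn1c(-c2ccc([N+](=O)[O-])cc2)cnc1NC(=O)c1ccc(F)cc1` has not yet been measured

In this assay compound 3 gives 37000 nM, a number within the scatter of compound 1 at 46000 nM. The only other result, for compound 2, is a limit and not a number.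

Compound 4 carries nitro in place of chloro on an aromatic carbon, para to a large group (nitro in place of chloro on an aromatic carbon). Within the data shown here, no measured compound carries nitro, so the evidence is indirect. The nearest measured change at this place is a 1.2-fold lower number from compound 1 to compound 3 (0.09 log units; within the scatter), with chloro in place of bromo. The move of the chlorine gives only a floor, an at least 1.3-fold lower number from compound 2 to compound 3 (0.13 log units; that floor lies within the scatter), and so does an at least 1.0-fold higher number from compound 1 to compound 2 (0.03 log units; that floor lies within the scatter). None of these steps shows a change beyond the scatter, so no step beyond it is expected here, and no direction can be favoured. The larger size of the entering group still calls for a wide range.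

The expected change, as estimated, is a 1.2-fold lower number from compound 3 to compound 4 (0.06 log units; within the scatter). For compound 4 the estimated value is 32000 nM, with an expected range of 10000 nM to 50000 nM.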

Compound 4, half-maximal cytotoxic concentration: > 50000 nM
Compound 4: a limit, no number (the forecaster's own chance of this, stated with the estimate: 25%); middle value at least 1.5-fold (0.19 log units) from the limit.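

In this assay compound 4 gives > 50000 nM, which is a limit of the assay and not a number. Nitro on an aromatic carbon, para to a large group, therefore gives no lower number than chloro or bromo at this place, and the two steps are floors only: an at least 1.3-fold higher number from compound 3 to compound 4 (0.13 log units; that floor lies within the scatter), and an at least 1.0-fold higher number from compound 1 to compound 4 (0.03 log units; that floor lies within the scatter). The earlier compounds held only halogens here; with nitro, which brings hydrogen-bond acceptors where chloro has none, the series reaches the same limit as compound 2: the limit of > 50000 nM in this assay, at which 2 of the 4 values shown sit.

On these data alone, the true size of both steps stays unknown, and so does any order between compound 2 and compound 4, since neither has a number in this assay. As far as these compounds go, it also remains open whether an amine or a carboxylic acid at this same place would stay at the limit or give a number clearly lower than those of the halogen compounds.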